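The source may report more compounds than this note shows. Statements on the series, on what has been measured and on what is new or still open speak of the compounds shown alone.

Measured in an assay on isolated protein for inhibition of receptor-type tyrosine-protein phosphatase C (Homo sapiens), read by spectrophotometry; a higher number here means a weaker inhibitor, a lower number a stronger inhibitor:
Compound 1 `O=C(COc1ccc2cc(C(O)(C(F)(F)F)C(F)(F)F)c(O)cc2c1)Nc1nc2ccccc2s1` — compound 1 gives 10900 nM
Compound 2 `O=C(COc1ccc2cc(C(O)(C(F)(F)F)C(F)(F)F)c(O)cc2c1)N(c1ccccc1)c1ccccc1` — compound 2 gives 14900 nM

Compound 1 holds the lower of the two numbers, but its gap to compound 2 lies within the usual scatter, so the two measured compounds cannot be told apart in this assay on these data alone. Compound 3 `O=C(COc1ccc2cc(C(O)(C(F)(F)F)C(F)(F)F)c(O)cc2c1)Nc1cccc2ccccc12` differs from compound 1 in a single place: naphthalen-1-yl in place of 1,3-benzothiazol-2-yl on an amide-type nitrogen. Going by the values given here, no measured pair shows this exchange, so nothing in the data speaks for a shift in either direction. With both measured compounds sitting close together and the change confined to the group on the amide-type nitrogen, the account expects compound 3 to stay near compound 1. The expected step, a 1.1-fold higher number from compound 1 to compound 3 (0.04 log units; within the scatter), is none beyond the scatter. Compound 3 is accordingly estimated at 12000 nM in this assay, with a likely range from 5000 nM to 30000 nM.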

Compound 3, half-maximal inhibitory concentration: 29100 nM
The estimate for compound 3 lay 2.4-fold (0.38 log units) below the measured number; measured number inside the range.
By their numbers in this assay, from the lowest: compounds 1, 2 and 3 (each within the scatter of the next, the first and the last beyond it).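

The group on the amide-type nitrogen is not indifferent in this assay: naphthalen-1-yl in place of 1,3-benzothiazol-2-yl gives a 2.7-fold higher number from compound 1 to compound 3 (0.43 log units; beyond the scatter), a modest step, but one that lies beyond the scatter, as the earlier pair of values could not show. The exchange replaces a two-ring group holding nitrogen, sulfur and hydrogen-bond acceptors with an all-carbon two-ring group, so these features travel together and this single pair cannot separate them. Nothing available bears on why the number rises.

The compounds shown leave open whether the nitrogen or the sulfur of 1,3-benzothiazol-2-yl accounts for the step, which 1,3-benzoxazol-2-yl or quinolin-2-yl on the same amide-type nitrogen could help to settle. From the compounds shown here alone, how a carboxylic acid on that group would read also remains open.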